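Notes on the ring nitrogen of compound 3

The compounds below may be only part of what the source reports. "The series", "measured", "known", "first", "only" and "open" are said of these compounds alone.

Values measured in a functional assay on MHCC97H cells (Homo sapiens) for antiproliferative activity, read by MTT assay, with a stated time of 48 h; on this read-out higher numbers stand for weaker inhibition and lower numbers for stronger inhibition:
- compound 1 `COc1ccc2c(/C=C/C(=O)c3cc(N)c(OC)c(OC)c3)c[nH]c2c1`: 186 nM
- compound 2 `COc1ccc2c(/C=C/C(=O)c3cc(OC)c(OC)c([N+](=O)[O-])c3)c[nH]c2c1`: 289 nM
- compound 3 `COc1cc(C(=O)/C=C/c2c[nH]c3ccccc23)cc([N+](=O)[O-])c1OC`: 830 nM

Compound 3 carries the highest number of the three, with compound 3 at 830 nM against compound 2 at 289 nM and compound 1 at 186 nM. The change under consideration leads to compound 4 `COc1cc(C(=O)/C=C/c2cn(C)c3ccccc23)cc([N+](=O)[O-])c1OC`: methyl in place of hydrogen on an aromatic nitrogen. This places methyl in place of hydrogen on an aromatic nitrogen.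

For the measured compounds named here, no measured step touches that nitrogen, so the evidence is only indirect. The step of a 2.9-fold higher number from compound 2 to compound 3 (0.46 log units; beyond the scatter), with hydrogen in place of methoxy on an aromatic carbon, shows that one small change can move the number beyond the scatter. The step of a 1.6-fold higher number from compound 1 to compound 2 (0.19 log units; within the scatter), with nitro in place of amino on an aromatic carbon, stays within it. Neither gives a direction for the new change. In this assay a step no larger than the modest one is therefore expected, most likely within the scatter. A slight lean toward a lower number is a judgement and not a measured trend. The estimated change is a 1.5-fold lower number from compound 3 to compound 4 (0.18 log units; within the scatter). For compound 4 the expected value is 550 nM, with an estimated range from 170 nM to 1700 nM.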

Compound 4, half-maximal inhibitory concentration: 850 nM
For compound 4 the middle estimate is 1.5-fold (0.19 log units) below the measured one; the range from low to high includes it.
By their numbers in this assay, from the lowest: compounds 1 and 2 (each within the scatter of the next); then compounds 3 and 4 (each within the scatter of the next).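

In this assay, for the compounds shown here, the step of a 1.0-fold higher number from compound 3 to compound 4 (0.01 log units; within the scatter) is the first reading at this position, the aromatic nitrogen of the five-membered aromatic ring, and it lies within the scatter. For this pair, the hydrogen on that nitrogen can therefore be replaced by methyl without any difference that the read-out can resolve, so a free hydrogen there is not required to keep the number of compound 3. Nothing among the data given accounts for this result, so it stands as an observation about a single pair and not as a trend.

The compounds shown leave open whether the position also accepts something larger than methyl, such as a longer chain, a benzyl group or a chain ending in an amine or a carboxylic acid. Going by these compounds alone, they also leave open whether methyl on that nitrogen would read the same way in compound 1 or compound 2, which stand at lower numbers than compound 3 and differ from it elsewhere on the core, so the single pair here cannot be carried over to them.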